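The compounds below may be only part of what the source reports. "The series", "measured", "known", "first", "only" and "open" are said of these compounds alone.

Values in an ADME assay on microsomes from liver (Mus musculus) for metabolic stability (a lower number here means that the compound disappears faster, a higher number that the compound lasts longer), so far:
compound 1 `NCCNC(=O)C[C@H]1CC[C@]2(CC1)OO[C@]1(O2)C2CC3CC(C2)CC1C3` gives 1.07 h
compound 2 `O=C(C[C@H]1CC[C@]2(CC1)OO[C@]1(O2)C2CC3CC(C2)CC1C3)N1CCNCC1` gives 0.802 h
compound 3 `NC(=O)CNC(=O)C[C@@H]1CCC[C@]2(C1)OOC1(O2)C2CC3CC(C2)CC1C3` gives 0.622 h

Compound 3 with 0.622 h lies within the scatter of both other compounds. The change to compound 4 `NC1CCN(C(=O)C[C@@H]2CCC[C@]3(C2)OOC2(O3)C3CC4CC(C3)CC2C4)CC1` is 4-aminopiperidin-1-yl in place of (carbamoylmethyl)amino on a carbonyl carbon with 4-aminopiperidin-1-yl in place of (carbamoylmethyl)amino on a carbonyl carbon and the core of compound 3 kept. Going by the values given here, the only measured step of this kind is a 1.3-fold lower number from compound 1 to compound 2 (0.13 log units; within the scatter) on the core of compound 1, which differs from that of compound 3. No step beyond the scatter is therefore expected in this assay and no direction can be assigned. The estimate means a 1.0-fold higher number from compound 3 to compound 4 (0.02 log units; within the scatter) as the expected step. Compound 4 is expected at 0.65 h with 0.33 h to 1.25 h as the estimated range.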

Compound 4, half-life: 1.41 h
Beside the measured number, compound 4's estimate is 2.2-fold (0.34 log units) below it; the measured number lies above the stated range.
By their numbers in this assay, from the lowest: compounds 3, 2, 1 and 4 (each within the scatter of the next, the first and the last beyond it).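

In this assay, 4-aminopiperidin-1-yl in place of (carbamoylmethyl)amino on a carbonyl carbon gives a 2.3-fold higher number from compound 3 to compound 4 (0.36 log units; beyond the scatter), a modest step and the first beyond the scatter at this place. The earlier step, a 1.3-fold lower number from compound 1 to compound 2 (0.13 log units; within the scatter), stayed within the scatter on a different core. Nothing available accounts for the new step.

From the compounds shown here alone, whether the step belongs to the ring or to its amine stays open, as does its size on the core of compound 1. Plain piperidin-1-yl or a 4-carboxypiperidin-1-yl group on the core of compound 3 would separate these.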